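Ester to Amide on a Shared Core

The compounds below may be only part of what the source reports. "The series", "measured", "known", "first", "only" and "open" are said of these compounds alone.

Measured so far:
Compound 1 `CCCSc1nc(Cl)c2c(n1)N(CCNC(=O)OC(C)(C)C)C(C(=O)N1CCN(C)CC1)N2` gives 59300 nM in a functional assay on MGC-803 cells (Homo sapiens) for antiproliferative activity, read by MTT assay, with a stated time of 72 h; a higher number here means a weaker inhibitor, a lower number a stronger inhibitor.
Compound 2 `CCCSc1nc(Cl)c2c(n1)N(Cc1ccccc1)C(C(=O)OCC)N2` gives 18500 nM in this assay.

Compound 2 holds the lower of the two numbers, and compound 1 lies beyond the usual scatter from it. Compound 3 `CCCSc1nc(Cl)c2c(n1)N(Cc1ccccc1)C(C(=O)NCC(C)C)N2` differs from compound 2 in one place: isobutylamino in place of ethoxy on a carbonyl carbon. Among the measured compounds shown here, no measured pair shows this change, so no step for it can be read from the data. The expected step in this assay is small, perhaps a modest move toward a lower number, or none beyond the scatter: a 1.2-fold lower number from compound 2 to compound 3 (0.09 log units; within the scatter). Compound 3 is therefore estimated at 15000 nM, within a range from 5000 nM to 45000 nM.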

Compound 3, half-maximal inhibitory concentration: 58400 nM
Compound 3: middle estimate off by 3.9-fold (0.59 log units), on the low side; the whole stated range lies below it.
By their numbers in this assay, from the lowest: compound 2; then compounds 3 and 1 (each within the scatter of the next).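

In this assay, isobutylamino in place of ethoxy on a carbonyl carbon gives a 3.2-fold higher number from compound 2 to compound 3 (0.50 log units; beyond the scatter). This is the only change in a single place shown so far, and it shows that this position is not indifferent: on the shared core, going from ester to amide gives a weaker inhibitor here. Nothing available explains this step.

Still open, going by these compounds, is whether the amide link or the isobutyl chain accounts for the step. A methylamino group or a carboxylic acid at the same carbonyl carbon would help separate the two.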